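Taking one methoxy off compound 3

The compounds below may be only part of what the source reports. "The series", "measured", "known", "first", "only" and "open" are said of these compounds alone.

In a functional assay on HepG2 cells (Homo sapiens) for antiproliferative activity, read by MTT assay, with a stated time of 48 h (a lower number here means a stronger inhibitor of growth, a higher number a weaker inhibitor of growth), compound 1 `COC(=O)N1N=C(c2ccccc2)CC1c1cc(OC)c(OC)c(OC)c1` gives 3950 nM and compound 2 `COC(=O)N1N=C(c2ccc(OC)cc2)CC1c1cc(OC)c(OC)c(OC)c1` gives 1710 nM as measured numbers. Compound 3 `COC(=O)N1N=C(c2cc(OC)c(OC)c(OC)c2)CC1c1cc(OC)c(OC)c(OC)c1` gives 9720 nM as the highest of the three. Compound 4 `COC(=O)N1N=C(c2ccc(OC)c(OC)c2)CC1c1cc(OC)c(OC)c(OC)c1`, still unmeasured, carries hydrogen in place of methoxy on an aromatic carbon relative to compound 3. Going by the values given here, the one measured step that bears on this is a 2.3-fold lower number from compound 1 to compound 2 (0.36 log units; beyond the scatter) on adding a methoxy, but compound 3 goes against any simple gain from more methoxy groups. Compound 4 is expected to fall between compound 2 (1710 nM) and compound 3 (9720 nM). A modest expected move to a lower number in this assay is a 2.4-fold lower number from compound 3 to compound 4 (0.39 log units; beyond the scatter) as estimated. For compound 4 the estimate is 4000 nM (expected range 1700 nM to 9500 nM).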

Compound 4, concentration for 50% growth inhibition: 4210 nM
The estimate for compound 4 lay 1.1-fold (0.02 log units) below the measured number; the range from low to high includes it.
By their numbers in this assay, from the lowest: compound 2; then compounds 1 and 4 (each within the scatter of the next); then compound 3.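

In this assay, hydrogen in place of methoxy gives a 2.3-fold lower number from compound 3 to compound 4 (0.36 log units; beyond the scatter), so a methoxy at this position raises the number here, and the same change does not act alike on the two cores: the same change on two cores in this assay, a 2.3-fold lower number (0.36 log units; beyond the scatter) from compound 1 to compound 2 and a 2.3-fold higher number (0.36 log units; beyond the scatter) from compound 4 to compound 3, 5.3-fold (0.73 log units) apart, beyond the scatter of two such steps. A further methoxy gives a 2.5-fold higher number from compound 2 to compound 4 (0.39 log units; beyond the scatter), again towards a higher number. With 3,4-dimethoxyphenyl in place of phenyl, the result is a 1.1-fold higher number from compound 1 to compound 4 (0.03 log units; within the scatter), so the gain seen with compound 2 does not survive the second methoxy. Open, going by these compounds, is whether a hydroxyl, an amine or a chlorine on this ring would follow the same course as methoxy.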